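Chain Ends Swapped on a Guanidine Series

The source may report more compounds than this note shows. Statements on the series, on what has been measured and on what is new or still open speak of the compounds shown alone.

Compound 1 `CC(C)N1C(=O)C(=O)N=C1/N=C(\NOCc1ccccc1)Nc1ccc(Cl)c(Cl)c1`: > 1 h
Compound 2 `CC(C)N/C(=N\C1=NC(=O)C(=O)N1C(C)C)Nc1ccc(Cl)c(Cl)c1`: > 1 h
Compound 3 `CCCCCCN/C(=N\C1=NC(=O)C(=O)N1C(C)C)Nc1ccc(Cl)c(Cl)c1`: 0.579 h

In an in vitro ADME assay on microsomes from liver (Mus musculus) for metabolic stability, read by LC-MS (on this read-out lower numbers stand for a shorter-lived compound and higher numbers for a longer-lived compound), compound 1 reaches a limit of the read-out, > 1 h. Compound 2 also reaches a limit in this assay, > 1 h. Compound 3 is the only one of the three with a number in this assay, 0.579 h; the other two sit at the limit of > 1 h in this assay, at which 2 of the 3 values shown sit, so compound 3 stands below both. The step of an at least 1.7-fold lower number from compound 1 to compound 3 (0.23 log units; that floor lies within the scatter) and the step of an at least 1.7-fold lower number from compound 2 to compound 3 (0.23 log units; that floor lies within the scatter) both point the same way, though each rests on a floor inside the scatter. The step that the two limits leave unreadable from compound 1 to compound 2 cannot be sized.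

Compound 4 `CC(C)N1C(=O)C(=O)N=C1/N=C(\NCCN(C)C)Nc1ccc(Cl)c(Cl)c1` carries the change (dimethylamino in place of butyl on a saturated chain carbon, two bonds along the chain from an amine nitrogen). Going by the values given here, the hexyl chain of compound 3 is thus shortened and ends in a basic-looking amine, but no measured step tests that exact swap. What the data show is that the longest chain, compound 3, gave the lowest number, while the shorter isopropyl of compound 2 and the benzyloxy of compound 1 stayed at the limit.

Compound 4 is therefore expected to move back upward, by a 1.6-fold higher number from compound 3 to compound 4 (0.19 log units; within the scatter), a step that may itself lie within the scatter. Compound 4 is estimated at 0.9 h, somewhere between 0.4 h and 2 h.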

Compound 4, half-life: > 1 h
Compound 4: no number, only a limit (the forecaster's own chance of this, stated with the estimate: 30%); at least 1.1-fold (0.04 log units) between middle value and limit.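

Going by these compounds alone, with a 2-(dimethylamino)ethyl chain on the amine nitrogen, compound 4 joins compound 1 and compound 2 at the limit in this assay, which leaves compound 3 as the only compound with a number: the limit of > 1 h in this assay, at which 3 of the 4 values shown sit. Placing dimethylamino in place of butyl, on a saturated chain carbon two bonds along the chain from an amine nitrogen, gives an at least 1.7-fold higher number from compound 3 to compound 4 (0.23 log units; that floor lies within the scatter), so the series now has a readable step upward from the hexyl compound, though only its floor is known and that floor does not clear the usual scatter. The steps to compound 4 from compound 1 and from compound 2 cannot be read, and the three compounds at the limit cannot be ordered among themselves.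

As far as these compounds go, how far compound 4 lies past the limit remains open, and so does the true size of its step from compound 3. From the compounds shown here alone, it is also open whether the hexyl result depends on the length of the chain or on its plain carbon end, which an octyl chain, a 3-(dimethylamino)propyl chain or a hexyl chain ending in a carboxylic acid would help to separate.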